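Carbamoylmethyl to Benzoylcarbamoyl: an Expected Cell Tolerance Step

The source may hold more compounds than are shown below. What is called first, only, known or untested is meant among the compounds shown, and "the series" means these compounds.

Among the measured compounds shown here, compound 1 `Cc1cn([C@@H]2O[C@H](CO[Si](C)(C)C(C)(C)C)[C@@]3(OS(=O)(=O)C=C3NCC(N)=O)[C@H]2O[Si](C)(C)C(C)(C)C)c(=O)n(C)c1=O` holds the highest of the three numbers measured so far: in a functional assay on MT4 cells (Homo sapiens) (a higher number here means that more compound is tolerated, a lower number that less compound is tolerated), compound 1 gives 14900 nM. Compound 2 `Cc1cn([C@@H]2O[C@H](CO[Si](C)(C)C(C)(C)C)[C@@]3(OS(=O)(=O)C=C3NC(N)=O)[C@H]2O[Si](C)(C)C(C)(C)C)c(=O)n(C)c1=O` gives 3700 nM, and compound 3 `COC(=O)C(=O)CNC1=CS(=O)(=O)O[C@@]12[C@@H](CO[Si](C)(C)C(C)(C)C)O[C@@H](n1cc(C)c(=O)n(C)c1=O)[C@@H]2O[Si](C)(C)C(C)(C)C` gives 10300 nM. The step of a 4.0-fold lower number from compound 1 to compound 2 (0.60 log units; beyond the scatter) is modest but beyond the scatter, whereas a 1.4-fold lower number from compound 1 to compound 3 (0.16 log units; within the scatter) stays within it. Compound 4 `Cc1cn([C@@H]2O[C@H](CO[Si](C)(C)C(C)(C)C)[C@@]3(OS(=O)(=O)C=C3NC(=O)NC(=O)c3ccccc3)[C@H]2O[Si](C)(C)C(C)(C)C)c(=O)n(C)c1=O` has not been measured; it differs from compound 1 in that (benzoylcarbamoyl in place of carbamoylmethyl on an amine nitrogen). The nearest guide is the step to compound 2, where a carbamoyl group likewise replaced carbamoylmethyl on the amine nitrogen and the tolerated amount fell. A drop of similar size is therefore expected, a 3.0-fold lower number from compound 1 to compound 4 (0.47 log units; beyond the scatter). Compound 4 is estimated at 5000 nM, within 2000 nM to 13000 nM.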

Compound 4, half-maximal cytotoxic concentration: 3330 nM
Compound 4: middle estimate off by 1.5-fold (0.18 log units), on the high side, and the stated range covers the measured number.
By their numbers in this assay, from the lowest: compounds 4 and 2 (each within the scatter of the next); then compounds 3 and 1 (each within the scatter of the next).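

Benzoyl in place of the hydrogen on the amide-type nitrogen gives a 1.1-fold lower number from compound 2 to compound 4 (0.05 log units; within the scatter) in this assay, so the far larger benzoylcarbamoyl group reads the same as carbamoyl. It also keeps the gap to the other two, with a 4.5-fold lower number from compound 1 to compound 4 (0.65 log units; beyond the scatter) and a 3.1-fold lower number from compound 3 to compound 4 (0.49 log units; beyond the scatter), so among these four compounds the lower numbers go with a carbamoyl unit on the amine nitrogen, not with group size. No measurement here explains this.

Still open, on these data alone, is whether a simple acetyl or a chlorobenzoyl on that carbamoyl nitrogen would read the same.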